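Swapping a chlorophenyl for a methoxyphenyl on a quinoline amide

This account rests on a few compounds, and the source may have more. Where it says the series, first, only, none or still open, it means among the compounds named here.

Measured in a functional assay on NCI-H460 cells (Homo sapiens) for cytotoxicity, read by MTT assay, with a stated time of 72 h; a lower number here means a stronger inhibitor, a higher number a weaker inhibitor:
Compound 1 `COc1cc2c(Oc3ccc(NC(=O)c4cc(-c5cccc(Cl)c5)nc5ccccc45)cc3F)ccnc2cc1OCCCN1CCC(C)CC1` gives 65 nM.
Compound 2 `COc1ccc(-c2cc(C(=O)Nc3ccc(Oc4ccnc5cc(OCCCN6CCC(C)CC6)c(OC)cc45)c(F)c3)c3ccccc3n2)cc1` gives 110 nM.
Compound 3 `COc1cc2c(Oc3ccc(NC(=O)c4cc(-c5cccc(Cl)c5)nc5ccc(F)cc45)cc3F)ccnc2cc1OCCCN1CCCC1` gives 72 nM.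

Compound 2 differs from compound 1 in one place: 4-methoxyphenyl in place of 3-chlorophenyl on an aromatic carbon. That change gave a 1.7-fold higher number from compound 1 to compound 2 (0.23 log units; within the scatter). Compound 4 `COc1ccc(-c2cc(C(=O)Nc3ccc(Oc4ccnc5cc(OCCCN6CCCC6)c(OC)cc45)c(F)c3)c3cc(F)ccc3n2)cc1` is not yet measured; it differs from compound 3 in the same way: 4-methoxyphenyl in place of 3-chlorophenyl on an aromatic carbon. The surroundings of the change are the same in both pairs. This counts as the same change. The difference between the core of compound 1 and the core of compound 3 is not broken down here. Going by the values given here, since the two cores differ, the step measured from compound 1 to compound 2 is the only guide, and the expected step for compound 4 is a 1.7-fold higher number from compound 3 to compound 4 (0.22 log units; within the scatter), resting on a 1.7-fold higher number from compound 1 to compound 2 (0.23 log units; within the scatter). Compound 4 is therefore expected to give about 120 nM in this assay, likely between 60 nM and 250 nM.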

Compound 4, half-maximal inhibitory concentration: 250 nM
Beside the measured number, compound 4's estimate is 2.1-fold (0.32 log units) below it; the range from low to high includes it.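

In this assay, the swap to 4-methoxyphenyl from 3-chlorophenyl on the core of compound 3 gives a 3.5-fold higher number from compound 3 to compound 4 (0.54 log units; beyond the scatter), so here the swap yields a weaker inhibitor. Taken alone, only this step stands clear of the scatter, but the gap between it and the earlier step does not, so the two steps cannot be told apart: the same change on two cores in this assay, a 1.7-fold higher number (0.23 log units; within the scatter) from compound 1 to compound 2 and a 3.5-fold higher number (0.54 log units; beyond the scatter) from compound 3 to compound 4, 2.1-fold (0.31 log units) apart, within the scatter of two such steps. This fits a change that carries from one core to the other, yet two pairs do not show that its size is fixed or that it would hold on any further core.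

The swap alters both the substituent and where it sits on the phenyl ring, and the compounds shown leave open which of these matters. Also open, from the compounds shown here alone, is how a phenyl ring carrying a nitrile or an amine would compare.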